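From compound 3 to compound 4: one more carbonyl change

The source may hold more compounds than are shown below. What is called first, only, known or untested is meant among the compounds shown, and "the series" means these compounds.

Measured in a physicochemical assay for solubility, with a stated time of 24 h, at pH 2.2; a higher number here means a more soluble compound, a lower number a less soluble compound:
Compound 1 `O=C(NC[C@@H]1[C@H]2CN(C(=O)OCc3cc(Cl)cc(Cl)c3)C[C@@H]12)c1ccc2[nH]c(=O)oc2c1`: < 1 ug/mL
Compound 2 `O=C(NC[C@@H]1[C@H]2CN(C(=O)/C=C/c3cc(Cl)cc(Cl)c3)C[C@@H]12)c1ccc2[nH]c(=O)oc2c1`: < 1 ug/mL
Compound 3 `O=C(NC[C@@H]1[C@H]2CN(C(=O)C3CC3c3cc(Cl)cc(Cl)c3)C[C@@H]12)c1ccc2[nH]c(=O)oc2c1`: < 1 ug/mL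

Compound 3 gives < 1 ug/mL, which is a limit of the assay and not a number. The whole set looks the same, with the limit of < 1 ug/mL in this assay, at which 3 of the 3 values shown sit.

Compound 4 `O=C(NC[C@@H]1[C@H]2CN(C(=O)NCc3cc(Cl)cc(Cl)c3)C[C@@H]12)c1ccc2[nH]c(=O)oc2c1` carries a group of 10 heavy atoms (7 carbon, 1 nitrogen, 2 chlorine; one six-membered aromatic ring of carbon only) in place of a group of 11 heavy atoms (9 carbon, 2 chlorine; one three-membered non-aromatic ring of carbon only, one six-membered aromatic ring of carbon only), on a carbonyl carbon. The group that enters is (3,5-dichlorobenzyl)amino.

Earlier changes on this carbonyl carbon give no size to work from. There is a step that the two limits leave unreadable from compound 1 to compound 2, then a step that the two limits leave unreadable from compound 1 to compound 3, and also a step that the two limits leave unreadable from compound 2 to compound 3. With no readable step, no change beyond the scatter and no direction is expected in this assay. The expected step is a step that the limit leaves unreadable from compound 3 to compound 4. The estimate for compound 4 is 0.7 ug/mL, with an expected range from 0.2 ug/mL to 2 ug/mL.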

Compound 4, solubility: < 1 ug/mL
Compound 4 was reported as a limit (the forecaster's own chance of this, stated with the estimate: 80%); the middle value does not contradict the limit.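

Compound 4 gives < 1 ug/mL in this assay, which is a limit and not a number. No step among compound 1, compound 2, compound 3 and compound 4 can be read: the limit of < 1 ug/mL in this assay, at which 4 of the 4 values shown sit.

On these data alone, whether these groups on the carbonyl carbon differ at all in solubility stays open.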